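Cyclohexyl in Place of Phenyl: Cytotoxicity Expected Unchanged

The source may report more compounds than this note shows. Statements on the series, on what has been measured and on what is new or still open speak of the compounds shown alone.

The measured compounds, each tested in an ADME assay on NCM460 cells (Homo sapiens) for cytotoxicity, read by MTT assay, with a stated time of 72 h; a lower number here means a stronger inhibitor, a higher number a weaker inhibitor:

compound 1 `Cc1ccc(NC(=O)c2cccc(/C=C3\CC(=O)N(c4ccccc4)C3=O)c2)cc1C` gives > 100000 nM, a limit of the assay and not a number.
compound 2 `O=C(Nc1ccc(OC(F)F)cc1)c1cccc(/C=C2\CC(=O)N(c3ccccc3)C2=O)c1` gives > 100000 nM, again a limit.
compound 3 `O=C(NCc1ccccc1)c1cccc(/C=C2\CC(=O)N(c3ccccc3)C2=O)c1` gives > 100000 nM, also a limit.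

Compound 3 therefore stands where every compound here stands: at the limit of > 100000 nM in this assay, at which 3 of the 3 values shown sit. None of the three compounds reached a measurable half-maximal inhibitory concentration in this assay, so the steps between them cannot be sized: a step that the two limits leave unreadable from compound 1 to compound 2, a step that the two limits leave unreadable from compound 1 to compound 3 and a step that the two limits leave unreadable from compound 2 to compound 3 all remain unreadable.

Compound 4 `O=C(NCC1CCCCC1)c1cccc(/C=C2\CC(=O)N(c3ccccc3)C2=O)c1` differs from compound 3 by cyclohexyl in place of phenyl on a saturated chain carbon bound to an amide-type nitrogen. Since each step measured so far has left cytotoxicity at the limit regardless of what sits on the amide-type nitrogen, the exchange of the aromatic ring for its saturated counterpart on the chain carbon gives no basis for expecting a change in this assay. The expected step of a number no higher from compound 3 to compound 4 (the limit leaves the size open) is none beyond the scatter. Compound 4 is therefore estimated at 100000 nM in this assay, with a range from 40000 nM to 300000 nM, and most likely it will again be reported only as a limit.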

Compound 4, half-maximal inhibitory concentration: > 100000 nM
Compound 4: no number, only a limit; the forecaster's own chance of this, stated with the estimate: 85%; the middle value sits exactly at the limit.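

Compound 4 gives > 100000 nM in this assay and this is a limit, not a number. Its steps to compound 1, compound 2 and compound 3 therefore cannot be read, and all four compounds stand together: the limit of > 100000 nM in this assay, at which 4 of the 4 values shown sit.

The compounds shown leave open whether in this assay any group on the amide-type nitrogen would give a measurable value.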